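A few compounds are considered here, and "the series" means these few. Any claim that something is new, unique, unknown or untested is made for them only; others in the source may bear on it.

Three measured compounds share one core, on which an amino group, a ketone that links to a substituted benzene ring, and an amino-linked second benzene ring all sit; compound 1 `COc1ccc(C(=O)c2sc(Nc3ccc(F)cc3)nc2N)cc1`, compound 2 `COc1cccc(C(=O)c2sc(Nc3ccccc3)nc2N)c1` and compound 3 `COc1cc(C(=O)c2sc(Nc3ccc(C)cc3)nc2N)cc(OC)c1OC` differ only in the groups placed on those two benzene rings. Each was tested in a functional assay on CCRF-CEM cells (Homo sapiens) for antiproliferative activity, read by cell counting, with a stated time of 2 days; on this read-out lower numbers stand for stronger inhibition and higher numbers for weaker inhibition. For compound 1 the assay reports > 10000 nM, which is a limit of the assay rather than a number, namely (the limit of > 10000 nM in this assay, at which 1 of the 3 values shown sits). Compound 2 gives 2300 nM. Compound 3 gives 41 nM, the lowest of the two numbers available, and the gap up to compound 2 lies well beyond the usual scatter of repeated measurements.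

The next compound, compound 4 `COc1cc(C(=O)c2sc(Nc3ccc(Cl)cc3)nc2N)cc(OC)c1OC`, is still to be measured. It differs from compound 3 in one place: chloro in place of methyl on an aromatic carbon. Within the data shown here, no measured pair shows this exchange, so there is nothing to point to for its size. The step is expected to be small, a 1.2-fold higher number from compound 3 to compound 4 (0.09 log units; within the scatter), not clearly beyond the scatter in either direction. Compound 4 is therefore estimated at 50 nM, most likely between 15 nM and 160 nM, to be compared with the value of compound 3 once it is known.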

Compound 4, half-maximal inhibitory concentration: 190 nM
Estimate against measurement, compound 4: 3.8-fold (0.58 log units) below; the measured number lies above the stated range.
By their numbers in this assay, from the lowest: compound 3; then compound 4; then compound 2. At a limit, above all of these: compound 1.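

Among these compounds, compound 3 and compound 4 form the first pair here that differs in one place only, so a single exchange can finally be read on its own, with nothing else changing on the molecule. Read in this assay the exchange of (4-methylphenyl)amino for (4-chlorophenyl)amino gives a 4.6-fold higher number from compound 3 to compound 4 (0.67 log units; beyond the scatter) while the benzene ring on the ketone stays the same, which shows that this position responds to the group it carries, even when one heavy atom simply replaces another, and that methyl gives the lower number of the two. Nothing measured here speaks to what lies behind this step, so its size stands without an explanation.

As far as these compounds go, how this position would respond to other groups, such as an ethyl group, an amine or a carboxylic acid, remains open, and so does the direction of any such change. Also open, from the compounds shown here alone, is whether exchanging methyl for chloro would give a step of similar size with other groups on the benzene ring attached to the ketone.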